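Chloro to methyl on the pyridinyl arm of compound 1

The compounds below may be only part of what the source reports. "The series", "measured", "known", "first", "only" and "open" are said of these compounds alone.

Going by the values given here, compound 1 `C[C@@H]1CN(c2ncccc2Cl)CCN1c1nc2ccc(C(C)(C)C)cc2[nH]1` holds the lower of the two numbers measured so far in a functional assay on HEK293 cells for antagonist activity at transient receptor potential cation channel subfamily V member 1 (Homo sapiens), read by FLIPR; on this read-out higher numbers stand for weaker inhibition and lower numbers for stronger inhibition: compound 1 gives 90.4 nM. Compound 2 `Cc1cc2nc(N3CCN(c4ncccc4Cl)C[C@H]3C)n(C)c2cc1C`, built on a different core, gives 3130 nM in this assay, a gap beyond the scatter, so compound 1 is the more potent of the two.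

Compound 3 `Cc1cccnc1N1CCN(c2nc3ccc(C(C)(C)C)cc3[nH]2)[C@H](C)C1` keeps the core of compound 1 and differs in a single point: methyl in place of chloro on an aromatic carbon, so the 3-chloropyridin-2-yl becomes a 3-methylpyridin-2-yl. Among the compounds with values here, no measured pair in this set shows the size of such a change, and the two groups are of the same count of heavy atoms with no donors or acceptors gained or lost. In this assay the expected change is a 1.7-fold higher number from compound 1 to compound 3 (0.22 log units; within the scatter), a small weakening at most, not clearly beyond the scatter. Compound 3 is estimated at 150 nM, with a range from 50 nM to 450 nM.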

Compound 3, half-maximal inhibitory concentration: 70.4 nM
Estimate against measurement, compound 3: 2.1-fold (0.33 log units) above, and the stated range covers the measured number.
By their numbers in this assay, from the lowest: compounds 3 and 1 (each within the scatter of the next); then compound 2.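

The step of a 1.3-fold lower number from compound 1 to compound 3 (0.11 log units; within the scatter) is the only single-point comparison shown in this assay, and it puts the 3-chloropyridin-2-yl and 3-methylpyridin-2-yl arms within the scatter of each other. At this position, on an aromatic carbon ortho to a large group and two atoms from the ring nitrogen, methyl therefore serves as well as chloro on the core of compound 1, so chloro is not required there for a number of this size. Nothing available explains why the two groups read alike.

The compounds shown leave open whether a methoxy, an amine or a carboxylic acid at this position would give a number in the same range. They also leave open whether methyl in place of chloro would read the same way on the core of compound 2.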